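Thiophene replaces cyclopentene on the aryl ring

The source may report more compounds than this note shows. Statements on the series, on what has been measured and on what is new or still open speak of the compounds shown alone.

Measured compounds:
Compound 1: `Cn1nc2c(=O)n(CC3(O)CCN(Cc4ccc(-c5ccncc5)cc4Cl)CC3)cnc2c1-c1ccc(CN)cc1` with 257 nM
Compound 2: `Cn1nc2c(=O)n(CC3(O)CCN(Cc4ccc(C5=CCCC5)cc4Cl)CC3)cnc2c1-c1ccc(CN)cc1` with 76.9 nM

In an assay on isolated protein for inhibition of ubiquitin carboxyl-terminal hydrolase 7 (Homo sapiens), with stated times of 30 min and 2 h (a higher number here means a weaker inhibitor, a lower number a stronger inhibitor), compound 2 gives 76.9 nM, the lowest of the two numbers shown; the nearest is compound 1, which in this assay gives 257 nM. Among the measured compounds shown here, the one measured step, a 3.3-fold lower number from compound 1 to compound 2 (0.52 log units; beyond the scatter), is modest and beyond the scatter. Compound 3 is `Cn1nc2c(=O)n(CC3(O)CCN(Cc4ccc(-c5cccs5)cc4Cl)CC3)cnc2c1-c1ccc(CN)cc1`; it differs from compound 2 by thiophen-2-yl in place of cyclopent-1-en-1-yl on an aromatic carbon. Thiophen-2-yl shares its aromatic character with the pyridin-4-yl of compound 1 and its size with the cyclopent-1-en-1-yl of compound 2, so the step from compound 1 to compound 2 bears only loosely on it. Compound 3 is therefore expected to land between the two measured numbers, with a step of a 1.4-fold higher number from compound 2 to compound 3 (0.16 log units; within the scatter) that may not pass beyond the scatter. The estimate for compound 3 in this assay is 110 nM, ranging from 45 nM to 280 nM.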

Compound 3, half-maximal inhibitory concentration: 38.6 nM
Estimate against measurement, compound 3: 2.8-fold (0.45 log units) above; measured number outside the range, below it.
By their numbers in this assay, from the lowest: compounds 3 and 2 (each within the scatter of the next); then compound 1.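

At this aromatic carbon, meta to a chloro group, a five-membered aromatic ring and a five-membered non-aromatic ring of carbon only cannot be told apart in this assay: the change gives a 2.0-fold lower number from compound 2 to compound 3 (0.30 log units; within the scatter) and thus stays within the usual scatter. Aromatic character alone therefore does not set compound 1 apart, for a change between two aromatic rings gives a 6.7-fold lower number from compound 1 to compound 3 (0.82 log units; beyond the scatter) in the same read-out. Nothing available accounts for either step.

Going by these compounds, what a phenyl, furan-2-yl or saturated cyclopentyl group would give at this carbon remains open, and with it whether the sulfur of thiophen-2-yl plays any part. Equally open, on these data alone, is whether the ring nitrogen or the ring size separates compound 1 from compound 3, and how an amine or a carboxylic acid on the thiophene ring would read.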